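Chain-end substituent at the aromatic nitrogen: pyrrolidinyl to anilinomethyl

A few compounds are considered here, and "the series" means these few. Any claim that something is new, unique, unknown or untested is made for them only; others in the source may bear on it.

Working notes on the series around compound 1 `N#Cc1nc2c(-c3nc4ccccc4[nH]3)c(N)n(CCN3CCCC3)c2nc1C#N`, which in a functional assay on HL-60 cells (Homo sapiens) for antiproliferative activity, read by MTT assay, with a stated time of 48 h (a lower number here means a stronger inhibitor, a higher number a weaker inhibitor), gives 4760 nM. Among the two plain numbers shown compound 1 stands at the highest; compound 2 `CN1CCN(CCn2c(N)c(-c3nc4ccccc4[nH]3)c3nc(C#N)c(C#N)nc32)CC1` gives 4300 nM, and the step of a 1.1-fold lower number from compound 1 to compound 2 (0.04 log units; within the scatter). Compound 3 `N#Cc1nc2c(-c3nc4ccccc4[nH]3)c(N)n(CCCO)c2nc1C#N` reaches only a limit of this assay, > 50000 nM. Against that limit the step of an at least 10-fold higher number from compound 1 to compound 3 (1.02 log units; beyond the scatter), and likewise an at least 11-fold higher number from compound 2 to compound 3 (1.06 log units; beyond the scatter); what bears on this is the limit of > 50000 nM in this assay, at which 1 of the 3 values shown sits.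

Compound 4 `N#Cc1nc2c(-c3nc4ccccc4[nH]3)c(N)n(CCCNc3ccccc3)c2nc1C#N` is not yet measured. It differs from compound 1 as follows: anilinomethyl in place of pyrrolidin-1-yl on a saturated chain carbon, two bonds along the chain from an aromatic nitrogen.

Within the data shown here, two measured steps bear on this change. Exchange of one saturated amine ring for another left the number where it was, as a 1.1-fold lower number from compound 1 to compound 2 (0.04 log units; within the scatter) shows. Replacing the ring by hydroxymethyl, a group that brings a hydrogen-bond donor and no ring, drove the number to the limit. Anilinomethyl also brings a hydrogen-bond donor, while retaining a ring, though an aromatic one of carbon only, so a weakening short of the limit is the expectation, with a 3.2-fold higher number from compound 1 to compound 4 (0.50 log units; beyond the scatter). Compound 4 is therefore estimated at 15000 nM, within 4000 nM to 50000 nM, with a real chance that only a limit is returned.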

Compound 4, half-maximal inhibitory concentration: 6920 nM
Compound 4: the middle estimate sits 2.2-fold (0.34 log units) above what was measured; measured number inside the range.
By their numbers in this assay, from the lowest: compounds 2, 1 and 4 (each within the scatter of the next). At a limit, above all of these: compound 3.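

In this assay, anilinomethyl stands level with both saturated amine rings, with a 1.5-fold higher number from compound 1 to compound 4 (0.16 log units; within the scatter) and a 1.6-fold higher number from compound 2 to compound 4 (0.21 log units; within the scatter), so among the compounds shown neither a saturated ring nor the lack of a hydrogen-bond donor is required at this position. Compound 4 also carries a hydrogen-bond donor, yet anilino in place of hydroxy gives an at least 7.2-fold lower number from compound 3 to compound 4 (0.85 log units; beyond the scatter), so the presence of a donor does not by itself separate compound 3 from the other compounds. That step gives only a minimum for the gap, as the value of compound 3 is a limit of the assay: the limit of > 50000 nM in this assay, at which 1 of the 4 values shown sits.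

Going by these compounds, it remains open whether the aromatic ring or the chain nitrogen of anilinomethyl separates compound 4 from compound 3, a question that a phenyl end group with no nitrogen, or a methyl on the anilino nitrogen, would address. Also open, on these data alone, is whether a chloroanilino group or a longer chain would move the number beyond the scatter of compound 1, compound 2 and compound 4.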